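Removing the chlorine from the chloromethyl group of compound 1

The compounds below may be only part of what the source reports. "The series", "measured", "known", "first", "only" and "open" are said of these compounds alone.

Three coumarin-derived esters have been tested in a functional assay on HT-1080 cells (Homo sapiens), read by transwell migration, with a stated time of 24 h, tested at 1 uM; a lower number here means a stronger effect, a higher number a weaker effect of the compound at the concentration tested. Compound 1 `O=C(Oc1cccc(Cl)c1)c1cc2cc(CCl)ccc2oc1=O` gives 79.8% in this assay. Compound 2 `NCc1ccc2oc(=O)c(C(=O)Oc3ccccc3)cc2c1` gives 85.5%, a value that lies within the scatter of compound 1. Compound 3 `CC(=O)NCc1ccc2oc(=O)c(C(=O)Oc3ccccc3)cc2c1` gives 63.5%, and compound 1 stands above compound 3 by an amount beyond the scatter. Among the compounds with values here, the single step between measured compounds that differ in one place, a number 22 percentage points lower from compound 2 to compound 3 (beyond the scatter), concerns an acetyl group placed on an amine nitrogen, and it has no counterpart in the change now considered.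

Compound 4 `Cc1ccc2oc(=O)c(C(=O)Oc3cccc(Cl)c3)cc2c1` has not yet been measured in this assay. It differs from compound 1 in one place: hydrogen in place of chloro on a saturated chain carbon bound to an aromatic carbon. Within the data shown here, no measured pair shows what removing a chloro group from a saturated chain carbon does here, so the expectation rests on the shared core of compound 1 and compound 4 and on the small size of the change. For that reason the step of a number 1.8 percentage points lower from compound 1 to compound 4 (within the scatter) is expected to stay within the scatter of repeated measurements. Compound 4 is therefore estimated at 78%, with a range from 62% to 93%.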

Compound 4, a percentage reported as activity, at one concentration (the size of the read-out at that concentration, not a potency): 52.5%
Estimate against measurement, compound 4: 25.5 percentage points above; the whole stated range lies above it.
By their numbers in this assay, from the lowest: compound 4; then compound 3; then compounds 1 and 2 (each within the scatter of the next).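

In this assay, the change from chloromethyl to methyl gives a number 27.3 percentage points lower from compound 1 to compound 4 (beyond the scatter), and this is the first step shown on a saturated chain carbon bound to an aromatic carbon. The chloro group at this place is therefore not a silent part of compound 1: the loss of one chlorine atom, with no ring, no hydrogen-bond donor or acceptor and no net charge involved, moves the read-out beyond the usual scatter, towards a stronger effect at the concentration tested. The chlorine is thus not needed for the effect seen here, yet nothing available on these compounds accounts for the size or direction of this step.

The compounds shown leave open how the read-out responds to other groups on this same carbon, such as a hydroxymethyl, a fluoromethyl or a longer chain, so one step cannot yet be extended into a trend. Also open, as far as these compounds go, is whether the same change would give a step of similar size with the phenyl ester carried by compound 2 and compound 3 in place of the chlorinated ester of compound 1 and compound 4.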